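This account rests on a few compounds, and the source may have more. Where it says the series, first, only, none or still open, it means among the compounds named here.

Measured so far in an ADME assay (liver) for metabolic stability, with Liver microsome (Homo sapiens) as the target, using microsomes, tested at 1 uM; on this read-out higher numbers stand for fast clearance and lower numbers for slow clearance:

Compound 1 `COc1cccc(OC)c1C1CCCC(=O)N1Cc1ccc2ccccc2c1`: > 1250 mL.min-1.g-1
Compound 2 `COc1cccc(OC)c1C1CCCC(=O)N1Cc1cccc(-c2ccccc2)n1`: > 1250 mL.min-1.g-1
Compound 3 `COc1cccc(OC)c1C1CCCC(=O)N1Cc1cccc(-c2ccccn2)c1`: > 1250 mL.min-1.g-1

None of these three entries is a true number, and the shared record is the limit of > 1250 mL.min-1.g-1 in this assay, at which 3 of the 3 values shown sit. Compound 3 stands at > 1250 mL.min-1.g-1, which is a limit of the assay. Going by the values given here, with limits alone, no order can be drawn among the three compounds, and no measured step is available as a guide.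

Compound 4 `COc1cccc(OC)c1C1CCCC(=O)N1Cc1cccc(-c2ncccn2)c1` differs from compound 3 in one place, on an aromatic carbon of a six-membered aromatic ring of carbon only, meta to a large group. There, pyrimidin-2-yl stands in place of pyridin-2-yl: pyrimidin-2-yl in place of pyridin-2-yl on an aromatic carbon.

The expectation in this assay is for a modest fall in clearance at most, one that may not exceed the usual scatter. The estimated change is an at least 1.2-fold lower number from compound 3 to compound 4 (0.09 log units; that floor lies within the scatter). Among the compounds with values here, this estimate is loose, since its only anchor is compound 3 with its limit of > 1250 mL.min-1.g-1. Another reading at the limit would be quite possible.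

For compound 4 the estimated value is 1000 mL.min-1.g-1, with an expected range from 400 mL.min-1.g-1 to 2500 mL.min-1.g-1.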

Compound 4, intrinsic clearance in microsomes: > 1250 mL.min-1.g-1
Compound 4 gave a limit, no number; the forecaster's own chance of this, stated with the estimate: 50%; middle value at least 1.2-fold (0.09 log units) away from the limit.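

In this assay compound 4 gives > 1250 mL.min-1.g-1, which is a limit of the assay and not a number. No step between compound 3 and compound 4 can be read, and the record stands at: the limit of > 1250 mL.min-1.g-1 in this assay, at which 4 of the 4 values shown sit.

The compounds shown leave open whether pyrimidin-2-yl in place of pyridin-2-yl alters clearance at all, and what true number any of these compounds has.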